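This account rests on a few compounds, and the source may have more. Where it says the series, first, only, none or still open, it means among the compounds named here.

In a functional assay on UACC-62 cells (Homo sapiens) for inhibition, read by sulforhodamine B assay, with a stated time of 48 h (on this read-out lower numbers stand for stronger inhibition of growth and higher numbers for weaker inhibition of growth), compound 2 `CC1(/C=C/c2ccccc2O)C=CC(=O)O1` gives 92500 nM and stands highest of the two measured compounds, weaker than compound 1 `CC1(/C=C/c2ccccc2C(F)(F)F)C=CC(=O)O1` at 17700 nM on this read-out. Compound 3 `COc1ccccc1/C=C/C1(C)C=CC(=O)O1` differs from compound 2 by methyl in place of hydrogen on an oxygen on an aromatic ring and so turns hydroxy to methoxy. For the measured compounds named here, the only measured step, a 5.2-fold higher number from compound 1 to compound 2 (0.72 log units; beyond the scatter), put hydroxy in place of trifluoromethyl on an aromatic carbon and bears only loosely on this change. Methoxy is neither of those two groups, so a smaller step towards a lower number is expected, namely a 2.3-fold lower number from compound 2 to compound 3 (0.36 log units; beyond the scatter), as an estimate. For compound 3 the estimated value is 40000 nM, with 15000 nM to 100000 nM as the expected range.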

Compound 3, concentration for total growth inhibition: 31000 nM
For compound 3 the middle estimate is 1.3-fold (0.11 log units) above the measured one, and the stated range covers the measured number.
By their numbers in this assay, from the lowest: compounds 1 and 3 (each within the scatter of the next); then compound 2.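

Putting methyl on the oxygen of the hydroxy group improves growth inhibition in this assay, with a 3.0-fold lower number from compound 2 to compound 3 (0.47 log units; beyond the scatter), so the hydrogen on this oxygen is not needed for this activity. Methoxy and trifluoromethyl cannot be told apart at this place, with a 1.8-fold higher number from compound 1 to compound 3 (0.24 log units; within the scatter), which leaves hydroxy as the only one of the three groups that stands apart. Nothing measured here explains this difference. As far as these compounds go, it remains open whether a longer chain on this oxygen, such as ethoxy, or an amine in place of methoxy would keep this level of inhibition.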